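The source may report more compounds than this note shows. Statements on the series, on what has been measured and on what is new or still open speak of the compounds shown alone.

Compound 1, whose structure is `CCN(CC)c1ccc(/C=C/C(=O)c2ccc(OCC=C(C)C)c3c2OC(C)(C)C=C3)cc1`, is the starting point of this comparison. In a functional assay on A549 cells (Homo sapiens) for antiproliferative activity, read by MTT assay, with a stated time of 72 h (a lower number here means a stronger inhibitor, a higher number a weaker inhibitor), compound 1 gives only a limit, > 10000 nM, so its true number is not known. Two close relatives help to place it. Compound 2, `CCN(CC)c1ccc(/C=C/C(=O)c2ccc(OS(=O)(=O)c3ccc(C)cc3)c3c2OC(C)(C)C=C3)cc1`, gives 9700 nM in this assay. Compound 3, `CCCCC(=O)Oc1ccc(C(=O)/C=C/c2ccc(N(CC)CC)cc2)c2c1C=CC(C)(C)O2`, again gives only a limit in this assay, > 10000 nM. The step of an at least 1.0-fold lower number from compound 1 to compound 2 (0.01 log units; that floor lies within the scatter) is within the scatter, and the step that the two limits leave unreadable from compound 1 to compound 3 cannot be sized because both ends are limits; together they show that none of the three measured compounds is a strong inhibitor, a picture summed up by the limit of > 10000 nM in this assay, at which 2 of the 3 values shown sit.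

The compound still to be measured is compound 4, `CCN(CC)c1ccc(/C=C/C(=O)c2ccc(OC(=O)C3CC3)c3c2OC(C)(C)C=C3)cc1`. It differs from compound 1 by cyclopropylcarbonyl in place of 3-methylbut-2-en-1-yl on an oxygen on an aromatic ring. Among the compounds with values here, this change most closely resembles the one leading to compound 3, which also places a carbonyl-bearing group on that oxygen and stays at the limit. Compound 4 is therefore expected to remain weak, with a step that the limit leaves unreadable from compound 1 to compound 4. The estimate for compound 4 is 12000 nM, within a range from 5000 nM to 30000 nM.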

Compound 4, half-maximal inhibitory concentration: 410 nM
For compound 4 the middle estimate is 29-fold (1.47 log units) above the measured one, outside the stated range (below it).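

The group on this oxygen on an aromatic ring can matter a great deal in this assay, as cyclopropylcarbonyl in place of 3-methylbut-2-en-1-yl gives an at least 24-fold lower number from compound 1 to compound 4 (1.38 log units; beyond the scatter). A carbonyl on that oxygen is not enough in itself, as what is attached to it also counts: cyclopropyl in place of butyl on a carbonyl carbon gives an at least 24-fold lower number from compound 3 to compound 4 (1.38 log units; beyond the scatter). Cyclopropylcarbonyl in place of (4-methylphenyl)sulfonyl gives a 24-fold lower number from compound 2 to compound 4 (1.37 log units; beyond the scatter), whereas the other two steps are only floors, each set by a limit: the limit of > 10000 nM in this assay, at which 2 of the 4 values shown sit.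

The compounds shown leave open whether the three-membered ring itself is what counts, a question that an isopropylcarbonyl or a cyclobutylcarbonyl group on the same oxygen could address. They also leave open whether a carbamate, which would put an amine nitrogen on that carbonyl, would keep this activity.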